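This account rests on a few compounds, and the source may have more. Where it says the series, first, only, none or still open, it means among the compounds named here.

Measured compounds:
compound 1 `COc1ccc(-c2cn(-c3cc(OC)c(OC)c(OC)c3)nn2)cc1` — > 10000 nM
compound 2 `COc1ccc(-c2cn(-c3cc(OC)c(OC)c(OC)c3)nn2)cc1Br` — > 10000 nM
compound 3 `COc1ccc(-c2cn(Cc3cc(OC)c(OC)c(OC)c3)nn2)cc1` — > 10000 nM

In a functional assay on K562 cells (Homo sapiens) for cytotoxicity, read by MTT assay, with a stated time of 5 days (a higher number here means a weaker inhibitor, a lower number a stronger inhibitor), compound 1 gives only a limit, > 10000 nM. In this assay compound 2 likewise gives only a limit, > 10000 nM. Compound 3 also gives only a limit in this assay, > 10000 nM. Compound 2 differs from compound 1 by bromo in place of hydrogen on an aromatic carbon, and the step that the two limits leave unreadable from compound 1 to compound 2 cannot be sized, because of the limit of > 10000 nM in this assay, at which 3 of the 3 values shown sit. Compound 3 carries a different core from compound 1, and the difference between the two cores is not broken down here. Compound 4 `COc1ccc(-c2cn(Cc3cc(OC)c(OC)c(OC)c3)nn2)cc1Br` is not yet measured; it differs from compound 3 by bromo in place of hydrogen on an aromatic carbon, the same change already made from compound 1 to compound 2. Since that earlier step that the two limits leave unreadable from compound 1 to compound 2 stayed within the limits, the step that the limit leaves unreadable from compound 3 to compound 4 in this assay is expected to be of similar, unreadable character. Compound 4 is therefore estimated at 15000 nM, with a range from 5000 nM to 50000 nM, most likely reported again only as a limit.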

Compound 4, half-maximal inhibitory concentration: > 10000 nM
Compound 4: only a limit was reported; the forecaster's own chance of this, stated with the estimate: 80%; the middle value is on the limit's open side.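

In this assay compound 4 gives > 10000 nM, which is a limit and not a number. No size can be read for the step from compound 3 to compound 4 because both compounds sit at the same limit: the limit of > 10000 nM in this assay, at which 4 of the 4 values shown sit.

The compounds shown leave open how strong any of them really is, and whether the bromo group or the change of core alters that.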